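The source may report more compounds than this note shows. Statements on the series, on what has been measured and on what is new or still open speak of the compounds shown alone.

Measured in a functional assay on HL-60 cells (Homo sapiens) for antiproliferative activity, read by MTT assay, with a stated time of 72 h; on this read-out lower numbers stand for stronger inhibition and higher numbers for weaker inhibition:
- compound 1 `NC1=NC2(CCOCC2)N(OCCCOc2cc(Cl)c(Cl)cc2Cl)C(N)=N1`: 2360 nM
- compound 2 `NC1=NC2(CCOCC2)N(OCCCOc2cccc(Br)c2)C(N)=N1`: 560 nM

Of these two, compound 2 has the lower number, at 560 nM. Compound 3 `NC1=NC2(CCOCC2)N(OCCCOc2cccc(Cl)c2)C(N)=N1` differs from compound 2 by chloro in place of bromo on an aromatic carbon, meta to a large group.

Within the data shown here, only one measured step bears on this change, and only indirectly: a 4.2-fold lower number from compound 1 to compound 2 (0.62 log units; beyond the scatter). That modest step alters the halogen pattern of the aryl group far more extensively than the present exchange does. Among the measured compounds shown here, no measured pair isolates chloro against bromo at this place. A single halogen exchange is therefore expected to give a smaller step, with no clear direction and nothing beyond the scatter in this assay. The estimate corresponds to an expected 1.2-fold higher number from compound 2 to compound 3 (0.06 log units; within the scatter). Compound 3 is expected at 650 nM, with an estimated range of 280 nM to 1500 nM.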

Compound 3, half-maximal inhibitory concentration: 520 nM
Estimate against measurement, compound 3: 1.3-fold (0.10 log units) above; low and high end bracket the measured number.
By their numbers in this assay, from the lowest: compounds 3 and 2 (each within the scatter of the next); then compound 1.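

In this assay, among these compounds, the exchange of bromo for chloro on an aromatic carbon, meta to a large group, gives a 1.1-fold lower number from compound 2 to compound 3 (0.03 log units; within the scatter) and is the first direct comparison of these two halogens at this place, which shows no separation between them. The 3-chlorophenyl group also stands clear of the 2,4,5-trichlorophenyl group, with a 4.5-fold lower number from compound 1 to compound 3 (0.66 log units; beyond the scatter) as the step, so the gain seen with the 3-bromophenyl group is not tied to bromo alone. No measurement available here explains why the two halogens match.

Still open, on these data alone, is whether a non-halogen group at this place, such as methoxy, trifluoromethyl or an amine, would hold the same level. Also open, as far as these compounds go, is how fluoro or a longer chain leading to the aromatic ring would behave.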